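The compounds below may be only part of what the source reports. "The series", "measured", "known", "first", "only" and "open" are said of these compounds alone.

Compound 1 `O=C1/C(=C\c2ccccc2)N=C(c2ccccc2)N1c1ccc2oc(-c3ccccc3)cc(=O)c2c1`: in a functional assay on the whole organism (strain Wistar) for inhibition, with Rattus norvegicus as the target, read by paw edema, with a stated time of 3 h, at a dose of 100 mg/kg by the oral route (on this read-out higher numbers stand for more inhibition at the one dose given (going by the name of the read-out) and lower numbers for less inhibition), compound 1 gives 38.3%.
Compound 2 `COc1ccc(/C=C2/N=C(c3ccccc3)N(c3ccc4oc(-c5ccccc5)cc(=O)c4c3)C2=O)cc1`: in this assay compound 2 gives 45.1%.
Compound 3 `COc1ccc(/C=C2/N=C(c3ccccc3)N(c3ccc4oc(-c5ccccc5)cc(=O)c4c3)C2=O)cc1OC`: in this assay compound 3 gives 49.8%.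

Compound 3 has the highest of the three numbers. Against compound 2 the gap is within the scatter, so the two cannot be ranked; against compound 1 it stands clearly higher, by a number 11.5 percentage points higher from compound 1 to compound 3 (beyond the scatter).

Compound 4 `O=C1/C(=C\c2ccc(O)cc2)N=C(c2ccccc2)N1c1ccc2oc(-c3ccccc3)cc(=O)c2c1` has not yet been measured. It differs from compound 3 in one place: 4-hydroxyphenyl in place of 3,4-dimethoxyphenyl on a double-bonded chain carbon bound to a double-bonded ring carbon.

Two kinds of measured step bear on this change. Adding a single methoxy gave a number 6.8 percentage points higher from compound 1 to compound 2 (within the scatter) and a number 4.7 percentage points higher from compound 2 to compound 3 (within the scatter), each within the scatter, while the full pair gave a number 11.5 percentage points higher from compound 1 to compound 3 (beyond the scatter). Among the compounds with values here, compound 4 gives up both methoxy groups, which on these numbers should return the value toward that of compound 1, but it also brings in a hydroxyl, for which no measured step exists. The expected step in this assay is therefore a modest fall, a number 8.8 percentage points lower from compound 3 to compound 4 (within the scatter), with wide uncertainty because of the unmeasured hydroxyl.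

Compound 4 is estimated at 41%, in a range from 30% to 53%.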

Compound 4, a percentage reported as inhibition, in the whole organism at one dose (the size of the read-out at that dose, not a potency): 47.6%
Beside the measured number, compound 4's estimate is 6.6 percentage points below it, within the range that was stated.
By their numbers in this assay, from the lowest: compounds 1, 2, 4 and 3 (each within the scatter of the next, the first and the last beyond it).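

On a double-bonded chain carbon bound to a double-bonded ring carbon, 4-hydroxyphenyl can take the place of 3,4-dimethoxyphenyl in this assay with a number 2.2 percentage points lower from compound 3 to compound 4 (within the scatter), so this position accepts a group carrying a hydrogen-bond donor and no methoxy without a change that this read-out can resolve. Hydrogen in place of the methyl on the oxygen gives a number 2.5 percentage points higher from compound 2 to compound 4 (within the scatter), and hydroxy in place of hydrogen on the plain phenyl gives a number 9.3 percentage points higher from compound 1 to compound 4 (within the scatter), so the hydroxy compound cannot be told apart from any of its three neighbours, whereas the pair of methoxy groups remains the only change here with a step beyond the scatter, a number 11.5 percentage points higher from compound 1 to compound 3 (beyond the scatter). Nothing available here speaks to the reason for these numbers.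

Going by these compounds, whether an amine, a carboxylic acid or a longer alkoxy chain in place of the hydroxy would read the same remains open. A reading at one dose also leaves open how potent any of these compounds is, and whether compound 4 and compound 3 would separate at other doses.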